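Replacing a hydroxyphenyl ester with a methoxyphenyl ester

The source may report more compounds than this note shows. Statements on the series, on what has been measured and on what is new or still open speak of the compounds shown alone.

Three esters built on one shared core have been measured in an ADME assay on a cell-free system (plasma, Homo sapiens) for metabolic stability, with Plasma (Rattus norvegicus) as the target, read by HPLC, at pH 7.4; on this read-out lower numbers stand for a shorter-lived compound and higher numbers for a longer-lived compound. Compound 1 `CC(=O)Oc1ccccc1C(=O)O[C@H]1CO[C@H]2[C@@H]1OC[C@H]2O` gives 0.0183 h in this assay. Compound 2 `CC(=O)Oc1ccccc1C(=O)O[C@H]1CO[C@H]2[C@@H]1OC[C@H]2OC(=O)c1cccc(O)c1` gives 0.015 h, and compound 3 `CC(=O)Oc1ccccc1C(=O)O[C@H]1CO[C@H]2[C@@H]1OC[C@H]2OC(=O)C1CC1` gives 0.015 h. The step of a 1.2-fold lower number from compound 1 to compound 2 (0.09 log units; within the scatter) and the step of a 1.2-fold lower number from compound 1 to compound 3 (0.09 log units; within the scatter) are both small, and the step of no change at the digits printed from compound 2 to compound 3 (within the scatter) shows no movement at the digits reported. Compound 2 thus stands level with compound 3, the two together at the low end of the three numbers, while compound 1 sits only a little apart and within the scatter.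

Compound 4 `COc1ccccc1C(=O)O[C@@H]1CO[C@H]2[C@@H]1OC[C@@H]2OC(=O)c1ccccc1OC(C)=O` has not yet been measured in this assay. It differs from compound 2 by 2-methoxyphenyl in place of 3-hydroxyphenyl on a carbonyl carbon; the same difference, cut one bond further out, reads (3-hydroxyphenyl)carbonyl to (2-methoxyphenyl)carbonyl. Within the data shown here, the one measured step at this carbonyl carbon, no change at the digits printed from compound 2 to compound 3 (within the scatter), exchanged 3-hydroxyphenyl for cyclopropyl without moving the number, and the two steps leading from compound 1 also stayed within the scatter. Among the measured compounds shown here, nothing among the measured compounds therefore points to a change beyond the scatter, and compound 4 is expected to show no change at the digits printed from compound 2 to compound 4 (within the scatter). The estimate for compound 4 in this assay is 0.015 h, with a range from 0.008 h to 0.03 h.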

Compound 4, half-life: 0.0165 h
Estimate against measurement, compound 4: 1.1-fold (0.04 log units) below; the measured number falls inside the stated range.
By their numbers in this assay, from the lowest: compounds 2, 3, 4 and 1 (each within the scatter of the next).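

With 2-methoxyphenyl in place of 3-hydroxyphenyl on a carbonyl carbon whose other neighbours are oxygen next to a carbonyl group, this assay gives a 1.1-fold higher number from compound 2 to compound 4 (0.04 log units; within the scatter), so an aromatic ring with 0 hydrogen-bond donors reads the same, within the scatter, as one with 1 hydrogen-bond donor. The position now also holds a third group without leaving the scatter: the exchange of cyclopropyl for 2-methoxyphenyl gives a 1.1-fold higher number from compound 3 to compound 4 (0.04 log units; within the scatter), and adding the whole (2-methoxyphenyl)carbonyl group to the free hydroxyl gives a 1.1-fold lower number from compound 1 to compound 4 (0.04 log units; within the scatter). Nothing shown here accounts for this flat result.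

Going by these compounds, all the groups seen at this position are neutral carbocyclic rings, so it remains open whether an aminomethyl group, a carboxylic acid or a longer alkyl chain on this carbonyl carbon would move the number beyond the scatter. Also open, on these data alone, is whether the half-life in this assay would respond to a change in the acetyl-bearing ester that all four compounds keep.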